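Swapping a Halogenated Phenyl on the Triazole Nitrogen

The source may hold more compounds than are shown below. What is called first, only, known or untested is meant among the compounds shown, and "the series" means these compounds.

Compound 2 `N#CC1=C(N)Oc2c(c3nc4ccccc4nc3c3ccccc23)C12C(=O)N(Cc1cnnn1-c1cccc(Cl)c1)c1ccccc12` carries a 3-chlorophenyl group on an aromatic nitrogen of its five-membered ring. In an ADME assay on HUVEC cells (Homo sapiens) for antiproliferative activity, read by MTT assay, with a stated time of 48 h (a higher number here means a weaker inhibitor, a lower number a stronger inhibitor), compound 2 gives > 50000 nM, which is a limit of the assay and not a number. Compound 1 `N#CC1=C(N)Oc2c(c3nc4ccccc4nc3c3ccccc23)C12C(=O)N(Cc1cnnn1-c1ccccc1Cl)c1ccccc12`, the 2-chlorophenyl counterpart, gives > 50000 nM in this assay, again a limit. The step that the two limits leave unreadable from compound 1 to compound 2 cannot be read because of the limit of > 50000 nM in this assay, at which 2 of the 2 values shown sit. Compound 3 `N#CC1=C(N)Oc2c(c3nc4ccccc4nc3c3ccccc23)C12C(=O)N(Cc1cnnn1-c1ccc(Br)cc1)c1ccccc12` differs from compound 2 by 4-bromophenyl in place of 3-chlorophenyl on an aromatic nitrogen. Going by the values given here, no measured step other than the unreadable one just described bears on this change, and both values shown sit at the limit. Compound 3 is expected to give 60000 nM in this assay, with a range from 20000 nM to 200000 nM. The step that the limit leaves unreadable from compound 2 to compound 3 is estimated to be none beyond the scatter, and compound 3 will most likely also be reported only as a limit.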

Compound 3, half-maximal inhibitory concentration: > 50000 nM
Compound 3: no number, only a limit; the forecaster's own chance of this, stated with the estimate: 85%; the middle value does not contradict the limit.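

Compound 3 also gives only a limit of the assay and not a number, so its steps from compound 1 and from compound 2 cannot be read: the limit of > 50000 nM in this assay, at which 3 of the 3 values shown sit.

The compounds shown leave open how strongly any of the three acts in this assay, and whether the choice of halogen or its place on the phenyl ring makes any difference there.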